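The compounds below may be only part of what the source reports. "The series", "measured", "known", "first", "only" and "open" are said of these compounds alone.

Measured so far in a functional assay, read by spectrophotometry, with a stated time of 30 min; on this read-out higher numbers stand for weaker inhibition and lower numbers for stronger inhibition: compound 1 `CCOC(=O)[C@@H](NC(=O)/C=C/c1ccc(OC(C)=O)c(OC)c1)C(C)C` gives > 500000 nM, which is a limit of the assay rather than a number. Compound 2 `CCOC(=O)[C@H](CC(C)C)NC(=O)/C=C/c1ccc(O)c(OC)c1` gives 56100 nM. Compound 3 `CCOC(=O)[C@H](C)NC(=O)/C=C/c1ccc(OC(C)=O)c(OC)c1` gives 482000 nM.

Compound 3 stands highest of the two numbers; its nearest neighbour is compound 2, which lies well beyond the scatter below it. Compound 4 `CCOC(=O)[C@H](CC(C)C)NC(=O)/C=C/c1ccc(OC(C)=O)c(OC)c1` has not yet been measured. It differs from compound 3 by isopropyl in place of hydrogen on a saturated chain carbon, two bonds along the chain from an amide-type nitrogen and a carbonyl carbon. Among the compounds with values here, the one measured step that touches the same part of the molecule is an at least 1.0-fold lower number from compound 1 to compound 3 (0.01 log units; that floor lies within the scatter), where swapping isopropyl for methyl on the saturated chain carbon changed nothing beyond the scatter, and it starts from a limit, (the limit of > 500000 nM in this assay, at which 1 of the 3 values shown sits). Within the data shown here, compound 2, which carries the same isobutyl chain as compound 4 but a free phenol instead of an acetate, shows a far lower number, yet no step joins it to compound 4 directly. A modest drop, or none beyond the scatter, is therefore expected: a 1.9-fold lower number from compound 3 to compound 4 (0.29 log units; within the scatter). Compound 4 is estimated at 250000 nM, ranging from 70000 nM to 600000 nM.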

Compound 4, half-maximal inhibitory concentration: > 500000 nM
Compound 4 ended at the assay's limit; the forecaster's own chance of this, stated with the estimate: 25%; middle value at least 2.0-fold (0.30 log units) away from the limit.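

In this assay, within the data shown here, acetyl in place of hydrogen on an oxygen on an aromatic ring gives an at least 8.9-fold higher number from compound 2 to compound 4 (0.95 log units; beyond the scatter), the first step at this oxygen and one that lies beyond the scatter. With the acetyl kept, isopropyl in place of hydrogen on the saturated chain carbon gives an at least 1.0-fold higher number from compound 3 to compound 4 (0.01 log units; that floor lies within the scatter), so no gain from the isobutyl chain shows here, although this step is only a floor. Compound 1 and compound 4 both stand at a limit rather than a number, so the step joining them cannot be read: the limit of > 500000 nM in this assay, at which 2 of the 4 values shown sit.

How the chain would act with a free phenol stays open, as the isobutyl chain is the only one shown with that group. As far as these compounds go, what a longer chain on this carbon, or a carboxylic acid in place of the ester, would give also remains open.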